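The compounds below may be only part of what the source reports. "The series", "measured", "known", "first", "only" and "open" are said of these compounds alone.

Measured compounds

Compound 1 `CCNC(=O)c1noc(-c2cc(C(C)C)c(O)cc2O)c1-c1cc(CNC(C)=O)no1`: 167 nM in a functional assay on HCT-116 cells (Homo sapiens) for inhibition; a lower number here means a stronger inhibitor, a higher number a weaker inhibitor
Compound 2 `CCCN(CCC)Cc1cc(-c2c(C(=O)NCC)noc2-c2cc(C(C)C)c(O)cc2O)on1`: 183 nM
Compound 3 `CCNC(=O)c1noc(-c2cc(C(C)C)c(O)cc2O)c1-c1cc(C(=O)O)no1`: "not determined" (no result reported)

The shared core of compounds 1 to 3 carries an ethylcarbamoyl group and, on the neighbouring aromatic carbon, a further five-membered ring. Compound 1 and compound 2 differ only in the substituent on that outer ring, and the step of a 1.1-fold higher number from compound 1 to compound 2 (0.04 log units; within the scatter) shows that this exchange leaves the number essentially where it was. Compound 3 bears the 3-carboxy-1,2-oxazol-5-yl variant of the outer ring; for compound 3 no number in this assay was reported, so it stands without a position among the measured values.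

Compound 4 `CCNC(=O)c1noc(-c2cc(C(C)C)c(O)cc2O)c1-c1cnn(CC)c1` arises from compound 3 by the change (1-ethyl-1H-pyrazol-4-yl in place of 3-carboxy-1,2-oxazol-5-yl on an aromatic carbon). Going by the values given here, no measured step covers an exchange of the outer ring itself; the only step at hand, from compound 1 to compound 2, concerns a substituent on that ring and not the ring. It therefore gives no direction for this move, and the expectation rests on the observation that compound 1 and compound 2 sit close together while the outer ring stays the same. With no guide for the ring swap, the estimate for compound 4 is placed near that level with wide bounds: compound 4 is expected to give about 300 nM, within a range of roughly 60 nM to 1500 nM.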

Compound 4, half-maximal inhibitory concentration: 26 nM
Estimate against measurement, compound 4: 12-fold (1.06 log units) above; measured number outside the range, below it.
By their numbers in this assay, from the lowest: compound 4; then compounds 1 and 2 (each within the scatter of the next).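

In this assay the outer ring on this aromatic carbon turns out to matter: the exchange of 3-(acetamidomethyl)-1,2-oxazol-5-yl for 1-ethyl-1H-pyrazol-4-yl gives a 6.4-fold lower number from compound 1 to compound 4 (0.81 log units; beyond the scatter), whereas the substituent change between compound 1 and compound 2, with that ring kept, stayed within the scatter. Going by these compounds alone, the position therefore responds to the identity of the whole ring group more than the one substituent exchange on the 1,2-oxazol-5-yl ring suggested, although the step from compound 3 to compound 4 cannot be read, as compound 3 has no number. No measurement at hand accounts for this difference.

On these data alone, it remains open whether the step belongs to the 1H-pyrazol-4-yl ring or to its ethyl group, a question that a methyl group or a longer chain such as propyl on the same ring nitrogen, or a dimethylaminoethyl chain there, would address. Also open, as far as these compounds go, is whether the flat response to the substituent on the outer ring, seen only between acetamido and dipropylamino, would hold for a hydroxymethyl or a primary amine on that chain carbon.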